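A few compounds are considered here, and "the series" means these few. Any claim that something is new, unique, unknown or untested is made for them only; others in the source may bear on it.

Three compounds share one core and differ only in the aromatic group attached to a carbonyl carbon. Compound 1 `CN(C(=O)NC(=O)c1ccc(Cl)cc1Cl)c1nc(C(F)(F)F)c(C(=O)N/N=C/c2ccc(C(F)(F)F)cc2)s1` gives 8.42 ug/mL in a functional assay on MCF7 cells (Homo sapiens) for inhibition, read by MTT assay, with a stated time of 72 h (on this read-out lower numbers stand for stronger inhibition and higher numbers for weaker inhibition), and compound 2 `CN(C(=O)NC(=O)c1cccc(C(F)(F)F)c1)c1nc(C(F)(F)F)c(C(=O)N/N=C/c2ccc(C(F)(F)F)cc2)s1` gives 6.5 ug/mL. Compound 3 `CN(C(=O)NC(=O)c1ccc(C(F)(F)F)cc1)c1nc(C(F)(F)F)c(C(=O)N/N=C/c2ccc(C(F)(F)F)cc2)s1` stands at a limit of this assay, > 100 ug/mL, so no number is known for it (the limit of > 100 ug/mL in this assay, at which 1 of the 3 values shown sits). Compound 4 `CN(C(=O)NC(=O)c1c(F)cccc1F)c1nc(C(F)(F)F)c(C(=O)N/N=C/c2ccc(C(F)(F)F)cc2)s1` carries 2,6-difluorophenyl in place of 4-(trifluoromethyl)phenyl on a carbonyl carbon. The measured steps that bear on this change are an at least 11-fold higher number from compound 1 to compound 3 (1.07 log units; beyond the scatter) and an at least 15-fold higher number from compound 2 to compound 3 (1.18 log units; beyond the scatter), both large, each leading into the group that compound 4 now loses. Because an at least 11-fold higher number from compound 1 to compound 3 (1.07 log units; beyond the scatter) and an at least 15-fold higher number from compound 2 to compound 3 (1.18 log units; beyond the scatter) were both large, a large step downward is expected for compound 4 an at least 8.3-fold lower number from compound 3 to compound 4 (0.92 log units; beyond the scatter). Compound 4 is therefore estimated at 12 ug/mL, with a range from 3 ug/mL to 60 ug/mL.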

Compound 4, half-maximal inhibitory concentration: 35.3 ug/mL
Beside the measured number, compound 4's estimate is 2.9-fold (0.47 log units) below it; low and high end bracket the measured number.
By their numbers in this assay, from the lowest: compounds 2 and 1 (each within the scatter of the next); then compound 4. At a limit, above all of these: compound 3.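

With a 2,6-difluorophenyl group on the carbonyl carbon, this assay gives a number again, with an at least 2.8-fold lower number from compound 3 to compound 4 (0.45 log units; beyond the scatter), yet that number does not match the two best-reading compounds, with a 5.4-fold higher number from compound 2 to compound 4 (0.73 log units; beyond the scatter) and a 4.2-fold higher number from compound 1 to compound 4 (0.62 log units; beyond the scatter). This position therefore shows a middle level, and not only compounds that read well or sit out of range. Compound 3 remains a limit and not a number, so its step to compound 4 gives only a minimum size: the limit of > 100 ug/mL in this assay, at which 1 of the 4 values shown sits.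

Going by these compounds, how an unsubstituted phenyl, a pyridine ring or a simple amine would read at this carbonyl carbon stays open. So does the reading of a phenyl ring carrying a single fluorine.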